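Series notes: ethyl for methyl on the core nitrogen

This account rests on a few compounds, and the source may have more. Where it says the series, first, only, none or still open, it means among the compounds named here.

Measured so far in an assay on HEK-293T cells for antagonist activity at vitamin D3 receptor (Homo sapiens), read by a luciferase reporter, with a stated time of 24 h; on this read-out higher numbers stand for weaker inhibition and lower numbers for stronger inhibition:
compound 1, `CC(C)c1onc(-c2c(Cl)cccc2Cl)c1COc1ccc(-c2nc3ccc(C(=O)O)cc3n2C)cc1`, gives 7150 nM.
compound 2, `CC(C)c1onc(-c2c(Cl)cccc2Cl)c1COc1ccc(-c2nc3cc(C(=O)O)ccc3n2C)cc1`, gives 4410 nM.
compound 3, `CC(C)c1onc(-c2c(Cl)cccc2Cl)c1COc1ccc(-c2nc3ccc(C(=O)O)cc3n2CC2CCCCC2)c(F)c1`, gives 840 nM.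

Compound 1 has the highest number of the three. Compound 2, which places the carboxylic acid at another position of the core, sits within the scatter of compound 1, so the two cannot be ordered. Compound 3, which carries a cyclohexylmethyl group on the aromatic nitrogen and a fluorine on the central ring, stands beyond the scatter from compound 1 with a clearly lower number; with two structural changes at once this gap cannot be assigned to either one.

Compound 4, `CCn1c(-c2ccc(OCc3c(-c4c(Cl)cccc4Cl)noc3C(C)C)cc2)nc2ccc(C(=O)O)cc21`, is not yet measured. It differs from compound 1 by methyl in place of hydrogen on a saturated chain carbon bound to an aromatic nitrogen. Within the data shown here, no pair of measured compounds shows this change alone, so only the rough direction can be taken from compound 3. The step from compound 1 to compound 4 in this assay is expected to be a small lowering, a 1.6-fold lower number from compound 1 to compound 4 (0.20 log units; within the scatter), at the edge of the scatter. Compound 4 is therefore expected to give about 4500 nM, with a range from 1800 nM to 11000 nM.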

Compound 4, half-maximal inhibitory concentration: 5760 nM
The estimate for compound 4 lay 1.3-fold (0.11 log units) below the measured number; the measured number falls inside the stated range.
By their numbers in this assay, from the lowest: compound 3; then compounds 2, 4 and 1 (each within the scatter of the next).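

In this assay, among these compounds, the pair of compound 1 and compound 4 is the first to isolate a change on the chain at the aromatic nitrogen, methyl to ethyl, and it reads as a 1.2-fold lower number from compound 1 to compound 4 (0.09 log units; within the scatter). A single added carbon at this place therefore does not separate the two compounds beyond the scatter, so this step alone gives no sign that chain length here matters in this range. Nothing at hand bears on the reason for this result.

The cyclohexylmethyl group of compound 3 arrives together with a fluorine on the central ring, so what this larger group contributes on its own stays unresolved, and the series holds no intermediate chain to connect it with ethyl. Also open, from the compounds shown here alone, is how a longer chain such as propyl or butyl, or a chain ending in an amine, would read at this place, and whether methyl to ethyl gives the same result with the carboxylic acid placed as in compound 2.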